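Moving a Methyl Group from Compound 3 to Compound 4

The source may hold more compounds than are shown below. What is called first, only, known or untested is meant among the compounds shown, and "the series" means these compounds.

In a functional assay on KBVIN cells (Homo sapiens) for antiproliferative activity, read by sulforhodamine B assay, with a stated time of 3 days (a higher number here means that more compound is needed for the effect, a lower number that less compound is needed), compound 1 `CCC1=C(O)c2c(oc(-c3ccc(O)cc3)cc2=O)C(CC)(CC)C1=O` gives 20.6 uM, compound 2 `CCC1=C(O)c2c(oc(-c3ccc(Br)cc3)cc2=O)C(CC)(CC)C1=O` gives 15.7 uM and compound 3 `CCC1=C(O)c2c(oc(-c3ccc(C)cc3C)cc2=O)C(CC)(CC)C1=O` gives 8.52 uM. Compound 3 stands clearly apart only from compound 1, with a 2.4-fold lower number from compound 1 to compound 3 (0.38 log units; beyond the scatter), whereas the data show a 1.8-fold lower number from compound 2 to compound 3 (0.27 log units; within the scatter). Compound 4 `CCC1=C(O)c2c(oc(-c3ccc(C)c(C)c3)cc2=O)C(CC)(CC)C1=O` has the same atoms as compound 3, joined differently: 3,4-dimethylphenyl in place of 2,4-dimethylphenyl on an aromatic carbon, so 3,4-dimethylphenyl replaces 2,4-dimethylphenyl. Going by the values given here, no measured step isolates such a move. The nearest steps alter the same group on the shared core and remain small, from a 1.3-fold lower number from compound 1 to compound 2 (0.12 log units; within the scatter) to a 1.8-fold lower number from compound 2 to compound 3 (0.27 log units; within the scatter) and a 2.4-fold lower number from compound 1 to compound 3 (0.38 log units; beyond the scatter). No change beyond the scatter is therefore expected, and the expected step is a 1.2-fold higher number from compound 3 to compound 4 (0.07 log units; within the scatter). Compound 4 is estimated at 10 uM, with an expected range of 5 uM to 19 uM.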

Compound 4, concentration for half-maximal effect: 0.71 uM
The estimate for compound 4 lay 14-fold (1.15 log units) above the measured number; measured number outside the range, below it.
By their numbers in this assay, from the lowest: compound 4; then compounds 3, 2 and 1 (each within the scatter of the next, the first and the last beyond it).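

Moving one methyl group adds and removes no atom, yet replacing 2,4-dimethylphenyl with 3,4-dimethylphenyl gives a 12-fold lower number from compound 3 to compound 4 (1.08 log units; beyond the scatter) at this place on the shared core, so the arrangement of the two methyl groups matters far more than the earlier steps suggested. With a 22-fold lower number from compound 2 to compound 4 (1.34 log units; beyond the scatter) and a 29-fold lower number from compound 1 to compound 4 (1.46 log units; beyond the scatter) as well, 3,4-dimethylphenyl stands apart from every other group shown. No measurement at hand explains this jump. Still open, as far as these compounds go, is whether a longer chain such as ethyl, or an amine, in place of these methyl groups would keep the number this low.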